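Cyclobutyl to 2-methylcyclopropyl on the amide of the diazabicyclic core

The compounds below may be only part of what the source reports. "The series", "measured", "known", "first", "only" and "open" are said of these compounds alone.

Measured so far:
compound 1 `O=C(C1CCC1)N1CC2CC(C1)N2`: 16 nM
compound 2 `O=C(CC1C=CCC1)N1CC2CC(C1)N2`: 53 nM

In an assay on SH-EP1 cells for displacement of a labelled ligand from Neuronal acetylcholine receptor; alpha4/beta2 (Homo sapiens), read by scintillation counting (a lower number here means a stronger inhibitor, a higher number a weaker inhibitor), compound 1 gives 16 nM, the lowest of the two numbers. Going by the values given here, compound 2 gives 53 nM in this assay, a higher number than compound 1 and beyond the usual scatter; the two differ in the acyl group on the shared core, and no single-site step between them is drawn here.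

Compound 3 `C[C@H]1C[C@H]1C(=O)N1CC2CC(C1)N2` is not yet measured. Against compound 1 the change is 2-methylcyclopropyl in place of cyclobutyl on a carbonyl carbon, the same count of atoms arranged in a smaller ring with a methyl branch and two defined stereocentres.

Among the compounds with values here, no measured step covers this change. The acyl group stays small and carbocyclic, so the expected step of a 1.3-fold higher number from compound 1 to compound 3 (0.10 log units; within the scatter) is small, not beyond the scatter. Compound 3 is estimated at 20 nM, with a range from 7 nM to 60 nM.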

Compound 3, inhibition constant: 7 nM
Compound 3: middle estimate off by 2.9-fold (0.46 log units), on the high side; the range from low to high includes it.
By their numbers in this assay, from the lowest: compound 3; then compound 1; then compound 2.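

At the carbonyl carbon, the acyl group is sensitive to how its carbons are arranged, not only to how many there are. In this assay, 2-methylcyclopropyl in place of cyclobutyl gives a 2.3-fold lower number from compound 1 to compound 3 (0.36 log units; beyond the scatter), a modest step beyond the scatter, with 4 heavy atoms in both groups and no hydrogen-bond donors or acceptors in either. No measurement bears on the reason for this step.

The compounds shown do not separate the contribution of the methyl branch from that of the three-membered ring, and they leave open how unsubstituted cyclopropyl would read. Going by these compounds, the role of the two defined stereocentres also stays open, as does the effect of an open chain such as butyl at the same carbonyl carbon.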